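The compounds below may be only part of what the source reports. "The series", "measured", "known", "first", "only" and "open" are said of these compounds alone.

Series notes, kinetic solubility. Three compounds have numbers in a physicochemical assay for solubility, in phosphate buffer, measured as kinetic solubility, with a stated time of 1 h, at pH 7.4; a higher number here means a more soluble compound, a lower number a less soluble compound. Compound 1 `COc1ccc2nc(C)cc(OC3CCN(c4ccccc4)C3=O)c2c1` gives 215000 nM. Compound 2 `COc1ccc2nc(C)c(NC(=O)C(=O)Nc3cc(C)cc(C)c3)c(O)c2c1` gives 10000 nM. Compound 3 `COc1ccc2nc(C)cc(OCC(=O)Nc3cc(C)ccc3C)c2c1` gives 45500 nM, the second highest of the three: compound 2 sits lower, beyond the scatter, and compound 1 sits higher, also beyond the scatter. For the measured compounds named here, no pair among the measured compounds differs in one place only, so no single step is available. Compound 4 `COc1ccc2nc(C)cc(OCC(=O)Nc3ccncc3)c2c1` is unmeasured; it differs from compound 3 by pyridin-4-yl in place of 2,5-dimethylphenyl on an amide-type nitrogen. Going by the values given here, with no comparable step in hand, an upward step in this assay is expected, and the step from compound 3 to compound 4 is estimated as a 3.3-fold higher number from compound 3 to compound 4 (0.52 log units; beyond the scatter). Compound 4 is expected to give 150000 nM, within 50000 nM to 400000 nM.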

Compound 4, solubility: 91500 nM
The estimate for compound 4 lay 1.6-fold (0.21 log units) above the measured number, and the stated range covers the measured number.
By their numbers in this assay, from the lowest: compound 2; then compounds 3 and 4 (each within the scatter of the next); then compound 1.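

The series now has its first step that changes one place only: in this assay, pyridin-4-yl in place of 2,5-dimethylphenyl on an amide-type nitrogen gives a 2.0-fold higher number from compound 3 to compound 4 (0.30 log units; within the scatter). At this place, therefore, the exchange of the carbon-only aromatic ring for a ring holding one nitrogen does not separate the two compounds beyond the scatter. No measured evidence bears on the reason for this step.

Still open, on these data alone, is how an aliphatic amine or a carboxylic acid on this amide-type nitrogen would read. Whether either would move the number beyond the scatter cannot be told from these compounds.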